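Aryl swap on the saturated ring carbon of the shared core

The source may report more compounds than this note shows. Statements on the series, on what has been measured and on what is new or still open speak of the compounds shown alone.

Measured compounds:
- compound 1, `CC(=O)C1=C(C)NC(=O)NC1c1ccsc1` — in an assay on membranes from CHO cells for displacement of a labelled ligand from adenosine receptor A1 (Homo sapiens), read by scintillation counting, with a stated time of 60 min, tested at 1 uM (on this read-out higher numbers stand for more inhibition at the one concentration tested (going by the name of the read-out) and lower numbers for less inhibition), compound 1 gives 9%
- compound 2, `CC1=C(C(=O)OC2CCCC2)C(c2ccco2)NC(=O)N1` — in this assay compound 2 gives 1%

Among the measured compounds shown here, compound 2 has the lower of the two numbers so far; compound 1 sits higher by an amount that lies within the usual scatter of such measurements, so the two values do not separate from one another, and the inhibition in this assay of neither compound can be set apart from that of the other on this evidence. Both read-outs are small.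

Compound 3, `CC1=C(C(=O)OC2CCCC2)C(c2ccsc2)NC(=O)N1`, is not yet measured. It differs from compound 2 in one place: thiophen-3-yl in place of furan-2-yl on a saturated ring carbon

For the measured compounds named here, no step between two measured compounds isolates this change, since compound 1 and compound 2 differ in two places at once. What the two measured values show is that both a furan-2-yl compound and a thiophen-3-yl compound sit low in this assay. For compound 3 the expected step is a number 4 percentage points higher from compound 2 to compound 3 (within the scatter), a step within the scatter and not one beyond it in either direction. The estimate for compound 3 in this assay is 5%, with a range from -5% to 15%.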

Compound 3, a percentage reported as inhibition, at one concentration (the size of the read-out at that concentration, not a potency): 5%
Beside the measured number, compound 3's estimate shows no gap at the digits printed; measured number inside the range.
By their numbers in this assay, from the lowest: compounds 2, 3 and 1 (each within the scatter of the next).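

Among the compounds shown here, with compound 2 and compound 3, the aryl swap on the saturated ring carbon can be read alone for the first time: in this assay, thiophen-3-yl in place of furan-2-yl gives a number 4 percentage points higher from compound 2 to compound 3 (within the scatter) and so does not set the two compounds apart. The change on the carbonyl can now also be read alone, as cyclopentyloxy in place of methyl on a carbonyl carbon gives a number 4 percentage points lower from compound 1 to compound 3 (within the scatter) and again leaves the two compounds unseparated in this assay. Nothing available explains why neither change separates its pair.

Going by these compounds, both single-place readings involve only these groups, so it remains open whether a phenyl ring or an aminomethyl group on the saturated ring carbon would give a number beyond the scatter in this assay. The same question stands for a carboxylic acid or a longer alkoxy chain on the carbonyl carbon, and the compounds shown give no indication either way.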